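Methyl on the Shared Core: an Estimate for Compound 4

This account rests on a few compounds, and the source may have more. Where it says the series, first, only, none or still open, it means among the compounds named here.

Measured compounds:
- compound 1, `COc1cc(N(C)CCN(C)C)c(NC(=O)/C=C\C(C)C)cc1Nc1nccc(-c2cn(C)c3ccccc23)n1`: in a functional assay on A549 cells (Homo sapiens) for antiproliferative activity, read by MTT assay, with a stated time of 72 h (on this read-out higher numbers stand for weaker inhibition and lower numbers for stronger inhibition), compound 1 gives 612 nM
- compound 2, `COc1cc(N(C)CCN(C)C)c(NC(=O)/C=C\C(C)C)cc1Nc1nc(C)cc(-c2cn(C)c3ccccc23)n1`: in this assay compound 2 gives 1070 nM
- compound 3, `C=CC(=O)Nc1cc(Nc2nccc(-c3cn(C)c4ccc(F)cc34)n2)c(OC)cc1N(C)CCN(C)C`: in this assay compound 3 gives 329 nM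

The three compounds share a common core and were all tested in this assay. Compound 2 differs from compound 1 by a single change, (methyl in place of hydrogen on an aromatic carbon). That change produced a 1.7-fold higher number from compound 1 to compound 2 (0.24 log units; within the scatter), a step that stays within the usual scatter of the method.

Compound 3 carries a different core from compound 1; the difference between the two cores is not broken down here. Compound 3 shows the lowest of the three numbers, but its gap to compound 1 is within the scatter, while its gap to compound 2 lies beyond it.

The unmeasured compound 4, `C=CC(=O)Nc1cc(Nc2nc(C)cc(-c3cn(C)c4ccc(F)cc34)n2)c(OC)cc1N(C)CCN(C)C`, is related to compound 3 by methyl in place of hydrogen on an aromatic carbon. This is the same kind of change as that from compound 1 to compound 2, not the same one: in compound 3 the place is meta to a 5-fluoro-1-methyl-1H-indol-3-yl group, whereas in compound 1 it is meta to a 1-methyl-1H-indol-3-yl group. The step from compound 3 to compound 4 in this assay is expected to be a 1.7-fold higher number from compound 3 to compound 4 (0.23 log units; within the scatter), because the earlier change gave a 1.7-fold higher number from compound 1 to compound 2 (0.24 log units; within the scatter). Compound 4 is therefore estimated at 560 nM, with a range from 280 nM to 1100 nM.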

Compound 4, half-maximal inhibitory concentration: 1490 nM
Beside the measured number, compound 4's estimate is 2.7-fold (0.42 log units) below it; measured number outside the range, above it.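

In this assay, methyl in place of hydrogen on the aromatic carbon next to the ring nitrogen gives a 4.5-fold higher number from compound 3 to compound 4 (0.66 log units; beyond the scatter), while on the core of compound 1 the same change gives a 1.7-fold higher number from compound 1 to compound 2 (0.24 log units; within the scatter); only the first of these steps lies beyond the scatter. Both steps run in the same direction, towards weaker inhibition, and the gap between them does not exceed what repeated measurements would allow: the same change on two cores in this assay, a 1.7-fold higher number (0.24 log units; within the scatter) from compound 1 to compound 2 and a 4.5-fold higher number (0.66 log units; beyond the scatter) from compound 3 to compound 4, 2.6-fold (0.41 log units) apart, within the scatter of two such steps. Within the data shown here, the change therefore carried over from one core to the other in direction, but the two steps cannot be said to differ in size, and two pairs do not show that the core has no influence on the step or establish a rule for the wider series.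

The compounds shown leave open whether an ethyl group, a methoxy group or an amine on that same aromatic carbon would also move the number upwards, and by how much. They also leave open how the step would behave on a core carrying only one of the differences between compound 1 and compound 3, such as the fluorine on the indole with the amide side chain of compound 1.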